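This account rests on a few compounds, and the source may have more. Where it says the series, first, only, none or still open, it means among the compounds named here.

Measured compounds:

Compound 1, `C=C(c1ccc2c(c1)C=CC(C)(C)O2)c1ccc(OC)cc1NC(=O)CNC`, in a functional assay on A549 cells (Homo sapiens) for antiproliferative activity, read by MTT assay, with a stated time of 48 h (on this read-out lower numbers stand for stronger inhibition and higher numbers for weaker inhibition), gives 200 nM.
Compound 2, `C=C(c1cc(OC)c(OC)c(OC)c1)c1ccc(OC)cc1NC(=O)CNC`, in this assay gives 100 nM.
Compound 3, `C=C(c1ccc2c(c1)C=CC(C)(C)O2)c1ccc(OC)cc1NC(=O)CNCC`, in this assay gives 1180 nM.

The three compounds share an amide-linked side chain ending in a methylamino group, and they fall into two cores: the core of compound 1, which is also the core of compound 3, and the core of compound 2. How the two cores differ is not broken down here. Compound 2 has the lowest number of the three, and compound 1 lies within the usual scatter of it, so the two are not separated in this assay; compound 3 lies clearly beyond both.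

Compound 3 arises from compound 1 by one change, (methyl in place of hydrogen on a saturated chain carbon bound to an amine nitrogen), and that change gave a 5.9-fold higher number from compound 1 to compound 3 (0.77 log units; beyond the scatter). Compound 4, `C=C(c1cc(OC)c(OC)c(OC)c1)c1ccc(OC)cc1NC(=O)CNCC`, has not been measured. It arises from compound 2 by methyl in place of hydrogen on a saturated chain carbon bound to an amine nitrogen, the same change at the same place, this time on the core of compound 2.

The only basis for an expectation is that one measured step. Because the change from compound 1 to compound 3 gave a 5.9-fold higher number from compound 1 to compound 3 (0.77 log units; beyond the scatter), compound 4 is expected to sit at a higher number than compound 2, and the expected step is a 5.0-fold higher number from compound 2 to compound 4 (0.70 log units; beyond the scatter). The resulting estimate for compound 4 in this assay is 500 nM, expected to fall between 220 nM and 1200 nM.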

Compound 4, half-maximal inhibitory concentration: 260 nM
Beside the measured number, compound 4's estimate is 1.9-fold (0.28 log units) above it; measured number inside the range.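

In this assay, the change from methylamino to ethylamino on the core of compound 2 gave a 2.6-fold higher number from compound 2 to compound 4 (0.41 log units; beyond the scatter), so the number rises on this core as it did on the core of compound 1. The step therefore carries over in direction, and the two sizes are not separated: the same change on two cores in this assay, a 5.9-fold higher number (0.77 log units; beyond the scatter) from compound 1 to compound 3 and a 2.6-fold higher number (0.41 log units; beyond the scatter) from compound 2 to compound 4, 2.3-fold (0.36 log units) apart, within the scatter of two such steps. For the compounds shown here, this rests on a single pair on each of two cores, so it shows only that the change raised the number in both pairs, not that the step has a fixed size or would rise on any other core, and the gap between the two steps cannot be read as an effect of the core.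

The compounds shown leave open how far the trend runs along the amine itself, for example whether a primary amine, a dimethylamino group or a longer chain such as propylamino would continue the rise seen from methylamino to ethylamino. Going by these compounds, whether the same step holds on a third core, or in cell lines other than the one used here, also stays open.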